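The compounds below may be only part of what the source reports. "The series", "measured", "known", "first", "only" and "open" are said of these compounds alone.

In a functional assay on L1210 cells (Mus musculus) for inhibition, with a stated time of 48 h (a higher number here means a weaker inhibitor, a lower number a stronger inhibitor), compound 1 (`CNCCCCNCCCNC`) sits at the limit of > 100000 nM. Compound 2 (`CNCCCCNCCCCNC`) also sits at a limit, > 100000 nM. Among the measured compounds shown here, compound 3 (`CNCCCCCNCCCCNC`) gives 2000 nM, the only actual number so far. Compound 4 (`CNCCCCCNCCCCCNC`) differs from compound 3 by (methylamino)methyl in place of methylamino on a saturated chain carbon, four bonds along the chain from an amine nitrogen. For the measured compounds named here, the closest precedent is an at least 50-fold lower number from compound 2 to compound 3 (1.69 log units; beyond the scatter), the same change at the same place. Also relevant is an at least 50-fold lower number from compound 1 to compound 3 (1.69 log units; beyond the scatter), whereas a step that the two limits leave unreadable from compound 1 to compound 2 cannot be read. Both readable steps start from a limit, so a further but smaller drop is expected in this assay. The expected change is a 2.9-fold lower number from compound 3 to compound 4 (0.46 log units; beyond the scatter). The estimate for compound 4 is 700 nM, with an expected range of 100 nM to 6000 nM.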

Compound 4, half-maximal inhibitory concentration: 15000 nM
Estimate against measurement, compound 4: 21-fold (1.33 log units) below; measured number above the stated range.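

In this assay the same change on the same kind of carbon gives a 7.5-fold higher number from compound 3 to compound 4 (0.88 log units; beyond the scatter) in this step, against an at least 50-fold lower number from compound 2 to compound 3 (1.69 log units; beyond the scatter) in the earlier one, so its direction reverses. Among these compounds its effect therefore depends on the chain that carries it, and compound 3 lies lower than both compound 2 and compound 4. The earlier drop is only a minimum size, and the step from compound 1 to compound 2 cannot be read: the limit of > 100000 nM in this assay, at which 2 of the 4 values shown sit.

Going by these compounds, whether a longer chain such as 3-(methylamino)propyl at this place raises the number further remains open. So does the effect of a hydroxyl or a primary amine in place of the terminal methylamino.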